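Ethyl for hydrogen on the core of compound 2

The source may hold more compounds than are shown below. What is called first, only, known or untested is meant among the compounds shown, and "the series" means these compounds.

Measured so far:
compound 1, `COc1ccc(-c2noc(-c3ccc(OC)cc3)c2C)cc1`: > 100000 nM
compound 2, `Oc1ccc(-c2cc(-c3ccc(O)cc3)on2)cc1`: 2500 nM

In an ADME assay (Mus musculus) for antiproliferative activity, read by cell counting, with a stated time of 5 days (on this read-out lower numbers stand for stronger inhibition and higher numbers for weaker inhibition), compound 1 gives only a limit, > 100000 nM, and no number; that reading is the limit of > 100000 nM in this assay, at which 1 of the 2 values shown sits. For the measured compounds named here, compound 2 gives 2500 nM in this assay, the only number in the set. Going by the values given here, compound 1 and compound 2 differ from each other in more than one place, so their two values show no single step and are not compared further here.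

Compound 3, `CCc1c(-c2ccc(O)cc2)noc1-c1ccc(O)cc1`, is not yet measured. Against compound 2 the change is ethyl in place of hydrogen on an aromatic carbon. Among the compounds with values here, no measured step tells how this change acts in this assay. For compound 3 the expectation is a step of a 1.3-fold lower number from compound 2 to compound 3 (0.10 log units; within the scatter) from compound 2, that is none beyond the scatter of repeats. Compound 3 is estimated at 2000 nM, with a range from 500 nM to 8000 nM.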

Compound 3, half-maximal inhibitory concentration: 13000 nM
Estimate against measurement, compound 3: 6.5-fold (0.81 log units) below; measured number above the stated range.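

Ethyl in place of hydrogen on this aromatic carbon of the core is the first single change that can be read in this assay, and it gives a 5.2-fold higher number from compound 2 to compound 3 (0.72 log units; beyond the scatter). On this read-out, that step means weaker inhibition, so this position does not accept the change without loss, although compound 3 still gives a number, 13000 nM, and not a limit. For the compounds shown here, nothing measured so far bears on why the step has this size.

On these data alone, with only one substituent read at this position, it remains open whether the loss belongs to ethyl alone or extends to other groups. A longer chain such as propyl, or an amine or a carboxylic acid at this position, could show whether the number keeps rising or returns towards that of compound 2.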